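The source may hold more compounds than are shown below. What is called first, only, known or untested is meant among the compounds shown, and "the series" means these compounds.

Working notes on the series. Of the compounds shown here, two have numbers so far. Compound 1 `COc1ccccc1C(C)NC(=O)COc1cc(C(F)(F)F)c2c(-c3ccccc3)nn(C)c2n1` gives 158 nM in a functional assay on isolated protein for antagonist activity at Orexin receptor type 2 (Homo sapiens), read by fluorescence, FLIPR and calcium flux, with a stated time of 1 h; on this read-out lower numbers stand for stronger inhibition and higher numbers for weaker inhibition. Compound 2 `Cc1nn(C)c(C)c1C(C)NC(=O)COc1cc(C(F)F)c2c(C3CC3)nn(C)c2n1` gives 527 nM in this assay and stands as the higher of the two numbers, with compound 1 below it beyond the usual scatter.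

Compound 3 `Cc1nn(C)c(C)c1C(C)NC(=O)COc1cc(C(F)F)c2c(-c3ccccc3)nn(C)c2n1` differs from compound 2 by phenyl in place of cyclopropyl on an aromatic carbon. Among the compounds with values here, no measured pair isolates this change; compound 1 also bears the phenyl but differs in other places as well, so its 158 nM hints only at direction. A moderate step toward a lower number is expected, a 2.0-fold lower number from compound 2 to compound 3 (0.31 log units; beyond the scatter), not far beyond the scatter. Compound 3 is estimated at 260 nM, within 100 nM to 700 nM.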

Compound 3, inhibition constant in the Orexin receptor type 2 assay: 59 nM
The estimate for compound 3 lay 4.4-fold (0.64 log units) above the measured number, outside the stated range (below it).
By their numbers in the Orexin receptor type 2 assay, from the lowest: compound 3; then compound 1; then compound 2.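

Within the data shown here, on this aromatic carbon, phenyl in place of cyclopropyl gives, in the Orexin receptor type 2 assay, an 8.9-fold lower number from compound 2 to compound 3 (0.95 log units; beyond the scatter), the first reading of this change with the rest of the structure held constant. The change therefore has a real effect on this read-out, and it does not come free. In a physicochemical assay for solubility, measured as thermodynamic solubility, at pH 6.8 (on this read-out higher numbers stand for higher solubility and lower numbers for lower solubility), compound 2 gives 657000 nM and compound 3 gives 248000 nM and the same change thus comes with lower solubility: the measured solubility of compound 2, 657000 nM, and of compound 3, 248000 nM, a 2.6-fold lower number (0.42 log units; beyond the scatter)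

The compounds shown leave open how a pyridyl ring or a tert-butyl group on this carbon would compare with phenyl. They also leave open whether the step holds when the rest of the structure differs.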